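This account rests on a few compounds, and the source may have more. Where it says the series, first, only, none or still open, it means among the compounds named here.

Working notes on the series.

For the measured compounds named here, compound 1 `CCOc1ccc(NC(=O)c2cccc(/C=C3\CC(=O)N(c4ccccc4)C3=O)c2)cc1` is the one member of the set that gives a number in an ADME assay on SW480 cells (Homo sapiens) for cytotoxicity, read by MTT assay, with a stated time of 72 h; a higher number here means a weaker inhibitor, a lower number a stronger inhibitor: in this assay compound 1 gives 91500 nM. Compound 2 `Cc1ccc(N2C(=O)C/C(=C\c3cccc(C(=O)Nc4ccc(Cl)cc4)c3)C2=O)cc1` gives only a limit of the assay in this assay, > 100000 nM; it is a limit and not a number (the limit of > 100000 nM in this assay, at which 1 of the 2 values shown sits). Between the two values shown for compound 1 and compound 2 no order can be read. Going by the values given here, no step between two measured compounds is available.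

Compound 3 `O=C(Nc1cccc(F)c1)c1cccc(/C=C2\CC(=O)N(c3ccccc3)C2=O)c1` is not yet measured. It differs from compound 1 by one change (3-fluorophenyl in place of 4-ethoxyphenyl on an amide-type nitrogen), and nothing measured in the set tells how this assay answers that change. With compound 1 at 91500 nM, the step of a 1.0-fold higher number from compound 1 to compound 3 (0.02 log units; within the scatter) is expected to be none beyond the usual scatter. Compound 3 is expected at 95000 nM, with a range from 40000 nM to 200000 nM.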

Compound 3, half-maximal inhibitory concentration: > 100000 nM
Compound 3: a limit, no number; the forecaster's own chance of this, stated with the estimate: 45%; middle value at least 1.0-fold (0.02 log units) away from the limit.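

3-fluorophenyl in place of 4-ethoxyphenyl on an amide-type nitrogen gives an at least 1.0-fold higher number from compound 1 to compound 3 (0.03 log units; that floor lies within the scatter) as the first step in the set that can be read. The reading of compound 3 in this assay is a limit and not a number, so this step has a floor and no upper end, and that floor does not separate the two compounds. The limit now holds most of the values in the set: the limit of > 100000 nM in this assay, at which 2 of the 3 values shown sit.

Still open, as far as these compounds go, is whether any group on this nitrogen brings a number clearly lower than that of compound 1 at 91500 nM in this series. A 4-aminophenyl or a 4-carboxyphenyl at this place, or a longer alkoxy chain in place of the ethoxy group, would bear on that question.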